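The compounds below may be only part of what the source reports. "The series", "measured", "known", "first", "only" and "open" are said of these compounds alone.

Compound 1 `C#Cc1cccc(Nc2ncnc3ccc(NC(=S)Nc4ccc(S(N)(=O)=O)cc4)cc23)c1`: in a functional assay on A549 cells (Homo sapiens) for antiproliferative activity, read by MTT assay, with a stated time of 72 h (a lower number here means a stronger inhibitor, a higher number a weaker inhibitor), compound 1 reaches only a limit of the assay, > 40000 nM.
Compound 2 `Cc1ccc(Nc2ncnc3ccc(NC(=S)Nc4ccc(S(N)(=O)=O)cc4)cc23)cc1`: in this assay compound 2 gives 2840 nM.

Compound 2 holds the only number shown in this assay; the one further value shown is a limit. The step from compound 1 to compound 2, a 4-methylphenyl in place of a 3-ethynylphenyl on a nitrogen on an aromatic ring, was an at least 14-fold lower number from compound 1 to compound 2 (1.14 log units; beyond the scatter), and it rests on (the limit of > 40000 nM in this assay, at which 1 of the 2 values shown sits), so its true size is not fixed. Compound 3 `CCc1ccc(Nc2ncnc3ccc(NC(=S)Nc4ccc(S(N)(=O)=O)cc4)cc23)cc1` differs from compound 2 by methyl in place of hydrogen on a saturated chain carbon bound to an aromatic carbon. No measured step touches this saturated chain carbon; the only step shown replaces the whole aryl group on that nitrogen. Extending methyl to ethyl on the 4-methylphenyl is a smaller change than the one measured, so no movement beyond the scatter is expected in this assay. For compound 3 the expected step from compound 2 is a 1.1-fold lower number from compound 2 to compound 3 (0.06 log units; within the scatter). Compound 3 is estimated at 2500 nM, with a range from 1000 nM to 7000 nM.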

Compound 3, half-maximal inhibitory concentration: 24600 nM
The estimate for compound 3 lay 9.8-fold (0.99 log units) below the measured number; the whole stated range lies below it.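

In this assay, the saturated chain carbon bound to an aromatic carbon proved sensitive: methyl in place of hydrogen there gave an 8.7-fold higher number from compound 2 to compound 3 (0.94 log units; beyond the scatter), so the change from 4-methylphenyl to 4-ethylphenyl moved the number beyond the scatter, and upward. The earlier step had replaced the whole aryl group on that nitrogen, whereas this one shows that a change confined to the chain on that aryl group can also matter. The comparison with compound 1 is less firm, with an at least 1.6-fold lower number from compound 1 to compound 3 (0.21 log units; that floor lies within the scatter), and since compound 1 reaches only a limit of the assay, this step gives a floor and not a size: the limit of > 40000 nM in this assay, at which 1 of the 3 values shown sits.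

Two compounds cannot show whether the number keeps rising or levels off along a longer chain such as propyl, or what an unsubstituted phenyl group would give. Going by these compounds, it also remains open whether a branched isopropyl or a methoxy group in the same place would behave like the methyl of compound 2 or the ethyl of compound 3.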